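The source may report more compounds than this note shows. Statements on the series, on what has been measured and on what is new or still open speak of the compounds shown alone.

Working notes on the series. Going by the values given here, compound 2 `O=C(CN1CCCCC1)NCCNc1cc(/C=C/c2ccccc2)nc2ccccc12` in an ADME assay on J774 cells (Mus musculus) for cytotoxicity, read by MTT assay, with a stated time of 48 h (on this read-out higher numbers stand for weaker inhibition and lower numbers for stronger inhibition), gives 4700 nM; the only other number, from compound 1 `CC(C)(C)OC(=O)NCCNc1cc(/C=C/c2ccccc2)nc2ccccc12` at 6600 nM, lies within the scatter of it, with a 1.4-fold lower number from compound 1 to compound 2 (0.15 log units; within the scatter). Compound 3 `O=C(CNc1ccc(Cl)cc1Cl)NCCNc1cc(/C=C/c2ccccc2)nc2ccccc12` differs from compound 2 by (2,4-dichlorophenyl)amino in place of piperidin-1-yl on a saturated chain carbon bound to a carbonyl carbon. Among the compounds with values here, the one step that bears on this site, from compound 1 to compound 2, was a 1.4-fold lower number from compound 1 to compound 2 (0.15 log units; within the scatter), so for compound 3 in this assay no step beyond the scatter is expected, estimated as a 1.2-fold lower number from compound 2 to compound 3 (0.07 log units; within the scatter). The expected value for compound 3 is 4000 nM, in a range from 1500 nM to 11000 nM.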

Compound 3, half-maximal inhibitory concentration: > 50000 nM
Compound 3: only a limit was reported; the forecaster's own chance of this, stated with the estimate: 5%; at least 12-fold (1.09 log units) between middle value and limit.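

In this assay, the group on a saturated chain carbon bound to a carbonyl carbon now shows a clear effect: (2,4-dichlorophenyl)amino in place of piperidin-1-yl gives an at least 10-fold higher number from compound 2 to compound 3 (1.02 log units; beyond the scatter), and ((2,4-dichlorophenyl)amino)methyl in place of tert-butoxy on a carbonyl carbon gives an at least 7.5-fold higher number from compound 1 to compound 3 (0.87 log units; beyond the scatter). The earlier step, a 1.4-fold lower number from compound 1 to compound 2 (0.15 log units; within the scatter), showed no such separation. The value of compound 3 is a limit and not a number: the limit of > 50000 nM in this assay, at which 1 of the 3 values shown sits.

The compounds shown leave open whether this step follows the aromatic ring, the two chlorines or the amine hydrogen. Phenylamino without chlorine and morpholin-4-yl on the same carbon would help separate these.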